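Adding a second phenyl to the benzyl ether of compound 1

This account rests on a few compounds, and the source may have more. Where it says the series, first, only, none or still open, it means among the compounds named here.

Measured compounds:
compound 1 `Cc1cnn(C(=O)NCc2ccc(OCc3ccccc3)cc2)c1`, 1200 nM
compound 2 `O=C(NCc1ccc(OCc2ccccc2)cc1)n1cccn1`, 800 nM
compound 3 `N#Cc1cnn(C(=O)NCc2ccc(OCc3ccccc3)cc2)c1`, 60 nM

In an assay on membranes from brain for binding affinity to Fatty-acid amide hydrolase 1 (Mus musculus), read by fluorescence, with stated times of 1 h and 30 min (a higher number here means a weaker inhibitor, a lower number a stronger inhibitor), compound 1 gives the highest of the three numbers. Its nearest neighbour is compound 2 (a 1.5-fold lower number from compound 1 to compound 2 (0.18 log units; within the scatter)), its furthest compound 3 (a 20-fold lower number from compound 1 to compound 3 (1.30 log units; beyond the scatter)). Compound 4 `Cc1cnn(C(=O)NCc2ccc(OC(c3ccccc3)c3ccccc3)cc2)c1` differs from compound 1 by phenyl in place of hydrogen on a saturated chain carbon bound to an aromatic carbon and an oxygen on an aromatic ring. The measured steps all change the substituent on the aromatic carbon of the shared core, not the benzylic ether carbon, so none of them bears on this change. The data give no basis for expecting a step beyond the scatter in this assay; compound 4 is therefore estimated at 1200 nM, with a range from 350 nM to 4000 nM, which corresponds to an expected step of no change at the digits printed from compound 1 to compound 4 (within the scatter).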

Compound 4, half-maximal inhibitory concentration: > 100000 nM
Compound 4 ended at the assay's limit; the forecaster's own chance of this, stated with the estimate: 10%; middle value at least 83-fold (1.92 log units) away from the limit.
By their numbers in this assay, from the lowest: compound 3; then compounds 2 and 1 (each within the scatter of the next). At a limit, above all of these: compound 4.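

Phenyl in place of hydrogen on a saturated chain carbon bound to an aromatic carbon and an oxygen on an aromatic ring gives an at least 83-fold higher number from compound 1 to compound 4 (1.92 log units; beyond the scatter) in this assay and is the first change shown at this position. Compound 4 gives > 100000 nM as a limit of the assay, not a number: the limit of > 100000 nM in this assay, at which 1 of the 4 values shown sits. Within these compounds, this position does not accept a phenyl, which the earlier changes on the aromatic carbon could not show.

On these data alone, whether a methyl, a hydroxyl or an amine would be accepted on this carbon remains open. So does whether the cyano of compound 3 would offset the added phenyl.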